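Solubility of an aminopyrazine carboxylic acid and its methyl ester

The source may hold more compounds than are shown below. What is called first, only, known or untested is meant among the compounds shown, and "the series" means these compounds.

Of the compounds shown here, three have been measured in a physicochemical assay for solubility, read by HPLC, using the shake flask method, with a stated time of 2 h, at pH 2; a higher number here means a more soluble compound, a lower number a less soluble compound. For the measured compounds named here, compound 1 `N#Cc1ccc(-c2cnc(N)c(-c3ccc(N)nc3)n2)cc1` gives 208000 nM, and compound 2 `CS(=O)(=O)c1ccc(-c2cnc(N)c(-c3ccc(N)nc3)n2)cc1` gives 206000 nM; the change of a 1.0-fold lower number from compound 1 to compound 2 (0.00 log units; within the scatter) is the only measured step between two numbered values. Compound 3 `Nc1ncc(-c2ccc(C(=O)O)cc2)nc1-c1ccc(C(F)(F)F)cc1` stands apart: in this assay compound 3 gives < 5000 nM, which is a limit of the assay rather than a number, as the limit of < 5000 nM in this assay, at which 1 of the 3 values shown sits, records.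

Compound 4 `COC(=O)c1ccc(-c2cnc(N)c(-c3ccc(C(F)(F)F)cc3)n2)cc1` differs from compound 3 by one change: methyl in place of hydrogen on an oxygen next to a carbonyl group

Going by the values given here, no measured step bears on this particular change, and the step from compound 1 to compound 2 concerns a different part of the shared core, so it offers no direct guide. With compound 3 sitting at the limit, only a small step is expected for a step that the limit leaves unreadable from compound 3 to compound 4, and compound 4 is expected to give about 3000 nM, within a range from 1000 nM to 10000 nM, most likely again reported as a limit in this assay.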

Compound 4, solubility: < 5000 nM
Compound 4: only a limit was reported (the forecaster's own chance of this, stated with the estimate: 70%); the middle value lies beyond the limit too.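

Compound 3 and compound 4 both stop at a limit of the assay, so no step can be read between them in this assay: the limit of < 5000 nM in this assay, at which 2 of the 4 values shown sit.

The compounds shown leave open how far each true solubility lies past that limit, and whether carboxy to methoxycarbonyl changes it at all.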